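Extending the sulfonyl group on the pyrazoline nitrogen

The source may report more compounds than this note shows. Statements on the series, on what has been measured and on what is new or still open speak of the compounds shown alone.

Measured compounds:
compound 1 `COC(=O)CC(=O)N1N=C(c2ccc(N3CCN(C)CC3)cc2)CC1c1ccc(N(C)C)cc1` — -2.2%
compound 2 `CN1CCN(c2ccc(C3=NN(C(=O)c4ccc(F)cc4)C(c4ccc(N(C)C)cc4)C3)cc2)CC1` — 32.2%
compound 3 `CN1CCN(c2ccc(C3=NN(S(C)(=O)=O)C(c4ccc(N(C)C)cc4)C3)cc2)CC1` — -1.3%

In a functional assay on NCI-H1975 cells (Homo sapiens) for inhibition, read by sulforhodamine B assay, tested at 10 uM (a higher number here means more inhibition at the concentration tested (going by the name of the read-out), a lower number less inhibition), compound 3 gives -1.3%, which lies within the scatter of compound 1 and far beneath compound 2: the step of a number 0.9 percentage points higher from compound 1 to compound 3 (within the scatter) is no real change, while a number 33.5 percentage points lower from compound 2 to compound 3 (beyond the scatter) is a large loss. Compound 4 `CN1CCN(c2ccc(C3=NN(S(=O)(=O)c4ccc(F)cc4)C(c4ccc(N(C)C)cc4)C3)cc2)CC1` differs from compound 3 in one place: 4-fluorophenyl in place of methyl on a sulfonyl sulfur.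

For the measured compounds named here, the most telling measured step is a number 34.4 percentage points higher from compound 1 to compound 2 (beyond the scatter), where a 4-fluorophenyl on a carbonyl carbon brought a large gain; compound 2 is the only measured compound with any activity in this assay. The change from compound 3 to compound 4 puts the same 4-fluorophenyl on a sulfonyl sulfur instead. Whether a sulfonyl carries the gain as a carbonyl did is not shown by any measured pair, so a moderate rise is expected, with a wide range: a number 19.3 percentage points higher from compound 3 to compound 4 (beyond the scatter). Compound 4 is therefore estimated at 18%, between -2% and 38%.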

Compound 4, a percentage reported as inhibition, at one concentration (the size of the read-out at that concentration, not a potency): 95.7%
Compound 4: the middle estimate sits 77.7 percentage points below what was measured; the whole stated range lies below it.
By their numbers in this assay, from the lowest: compounds 1 and 3 (each within the scatter of the next); then compound 2; then compound 4.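

On the sulfonyl sulfur, the size of the group decides the outcome in this assay: 4-fluorophenyl in place of methyl gives a number 97 percentage points higher from compound 3 to compound 4 (beyond the scatter), making compound 4 the highest of the four. The linking group counts as well, since with the 4-fluorophenyl kept, (4-fluorophenyl)sulfonyl in place of (4-fluorophenyl)carbonyl gives a number 63.5 percentage points higher from compound 2 to compound 4 (beyond the scatter), so the sulfonyl carries the aryl group further than the carbonyl did. Replacing the ((methoxycarbonyl)methyl)carbonyl group outright gives a number 97.9 percentage points higher from compound 1 to compound 4 (beyond the scatter), and nothing available explains these gains.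

The compounds shown leave open whether the fluorine is needed, which a plain phenyl or a 4-methoxyphenyl on the same sulfur would test. They also leave open whether an aromatic ring is needed at all, which a butyl chain or a cyclohexyl ring there would answer.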